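The compounds below may be only part of what the source reports. "The series", "measured", "known", "first", "only" and "open" are said of these compounds alone.

Measured in a physicochemical assay for lipophilicity, read by HPLC, at pH 7.5; a higher number here means a more lipophilic compound, a lower number a more polar compound:
compound 1 `CC[C@@H](Nc1c(C#N)c(-c2ccc(-c3cccc(Cl)c3F)cc2)nc2cnccc12)C(N)=O`: 3.1
compound 2 `CC[C@@H](Nc1c(C#N)c(-c2ccc(-c3ccc(Cl)cc3)cc2)nc2cnccc12)C(N)=O`: 3.1

On these numbers, compound 2, at 3.1, stands level with compound 1. The next structure is compound 3 `CC[C@@H](Nc1c(C#N)c(-c2ccc(Br)cc2)nc2cnccc12)C(N)=O`, and the change is bromo in place of 4-chlorophenyl on an aromatic carbon: bromo enters in place of 4-chlorophenyl, para to a large group, and one six-membered aromatic ring of carbon only leaves.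

For the measured compounds named here, one measured step bears on this: no change at the digits printed from compound 1 to compound 2 (within the scatter). That step exchanged 3-chloro-2-fluorophenyl for 4-chlorophenyl and kept the ring, so it gives only weak guidance here. Going by the values given here, no measured step removes such a ring, and the size below rests on the structural change alone.

A fall beyond the scatter is expected in this assay, with an estimated a number 0.70 log units lower from compound 2 to compound 3 (beyond the scatter). Compound 3 is estimated at 2.4, with an expected range of 1.9 to 2.9.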

Compound 3, distribution coefficient: 2.2
For compound 3 the middle estimate is 0.20 log units above the measured one; measured number inside the range.
By their numbers in this assay, from the lowest: compound 3; then compounds 1 and 2 (each within the scatter of the next).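

In this assay this position responds when the ring is lost: bromo in place of 4-chlorophenyl gives a number 0.90 log units lower from compound 2 to compound 3 (beyond the scatter) while the earlier exchange of one chlorinated ring for another left the two numbers level. Bromo in place of 3-chloro-2-fluorophenyl gives a number 0.90 log units lower from compound 1 to compound 3 (beyond the scatter) so the fall appears from either ring-bearing compound. Nothing available accounts for the size of this fall.

Each of these steps removes the ring and brings in bromo at once, so the compounds shown leave open how much of the fall belongs to either part of the change. A methoxy group or an amine on this aromatic carbon, or the same groups on the retained ring, would show how far the number moves with other substituents.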